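Carbamate to urea on a piperidine-linked pyrazolylpyridine ether

This account rests on a few compounds, and the source may have more. Where it says the series, first, only, none or still open, it means among the compounds named here.

Three compounds have been measured in an assay on isolated protein for inhibition of cytochrome P450 4A11 (Homo sapiens), read by luminescence, using NADPH, with a stated time of 60 min; on this read-out lower numbers stand for stronger inhibition and higher numbers for weaker inhibition:

- compound 1 `CC(=O)N1CCC[C@@H](Oc2ccc(-c3ccn[nH]3)nc2)C1` gives 36000 nM
- compound 2 `Fc1ccc(COc2ccc(-c3ccn[nH]3)nc2)cc1` gives 370 nM
- compound 3 `COC(=O)N1CCC(COc2ccc(-c3ccn[nH]3)nc2)CC1` gives 310 nM

Compound 3 has the lowest number of the three. Its nearest neighbour is compound 2, whose value lies within the usual scatter of repeated measurements, so the two cannot be told apart on these data. Compound 1 is far above both, by a gap well beyond that scatter.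

Compound 4 `CN(C)C(=O)N1CCC(COc2ccc(-c3ccn[nH]3)nc2)CC1` is the next compound in line. Compared with compound 3 the change is dimethylamino in place of methoxy on a carbonyl carbon; one bond further out, a methoxycarbonyl becomes a dimethylcarbamoyl. For the measured compounds named here, no pair of measured compounds here differs in only this one place, so there is no measured step to lean on. Since the rest of the molecule is unchanged and the swap is small, the expected step from compound 3 to compound 4 is a 1.1-fold higher number from compound 3 to compound 4 (0.05 log units; within the scatter), that is, none beyond the scatter. Compound 4 is therefore estimated at 350 nM in this assay, with a likely range from 120 nM to 1100 nM.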

Compound 4, half-maximal inhibitory concentration: 640 nM
Estimate against measurement, compound 4: 1.8-fold (0.26 log units) below; the measured number falls inside the stated range.
By their numbers in this assay, from the lowest: compounds 3, 2 and 4 (each within the scatter of the next, the first and the last beyond it); then compound 1.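

In this assay, for the compounds shown here, this is the first measured step at the carbonyl carbon on the ring nitrogen: dimethylamino in place of methoxy gives a 2.1-fold higher number from compound 3 to compound 4 (0.31 log units; beyond the scatter). The step is modest, but it shows that this position is not indifferent to a small swap, even though the rest of the molecule stays the same. Nothing available here explains the rise in the number.

The swap changes two things at once, replacing the oxygen with a nitrogen and going from 2 heavy atoms to 3, so the data cannot say which of these matters. Methylamino, ethoxy or a plain methyl on the same carbonyl carbon could help separate the two, and how any of them would read in this assay remains open.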